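Cytotoxicity of three analogues and a chlorophenyl congener

This account rests on a few compounds, and the source may have more. Where it says the series, first, only, none or still open, it means among the compounds named here.

Compound 1 `CCn1cc(C(=O)N2N=C(c3cc4ccccc4o3)CC2c2ccccc2OC)c(=O)c2ccc(C)nc21` in an ADME assay on Vero cells (Chlorocebus sabaeus) for cytotoxicity, read by MTT assay, with a stated time of 72 h (on this read-out lower numbers stand for stronger inhibition and higher numbers for weaker inhibition), gives > 187000 nM, which is a limit of the assay.
Compound 2 `CCn1cc(C(=O)N2N=C(c3cc4ccccc4o3)CC2c2ccccc2C(=O)O)c(=O)c2ccc(C)nc21` in this assay gives > 196000 nM, which is a limit of the assay.
Compound 3 `CCn1cc(C(=O)N2N=C(c3cc4ccccc4o3)CC2c2cccc([N+](=O)[O-])c2)c(=O)c2ccc(C)nc21` in this assay gives > 164000 nM, which is a limit of the assay.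

Compound 3 thus stands only at a limit in this assay, and the two further values shown are limits as well, as the limit of > 164000 nM in this assay, at which 1 of the 3 values shown sits, the limit of > 187000 nM in this assay, at which 1 of the 3 values shown sits, and the limit of > 196000 nM in this assay, at which 1 of the 3 values shown sits, record. Compound 4 `CCn1cc(C(=O)N2N=C(c3cc4ccccc4o3)CC2c2ccccc2Cl)c(=O)c2ccc(C)nc21` differs from compound 3 in one place: 2-chlorophenyl in place of 3-nitrophenyl on a saturated ring carbon. Within the data shown here, three measured steps bear on such a change at that saturated ring carbon, yet none of them yields a size: a step that the two limits leave unreadable from compound 1 to compound 3, a step that the two limits leave unreadable from compound 2 to compound 3 and a step that the two limits leave unreadable from compound 1 to compound 2 are all left unreadable by the limits at both ends. Nothing shown therefore points to a step beyond the scatter in this assay in either direction, and the expectation is that compound 4 again falls at or beyond the limit. The estimated step is a step that the limit leaves unreadable from compound 3 to compound 4. For compound 4 the expected value in this assay is 200000 nM, within a range from 90000 nM to 450000 nM.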

Compound 4, half-maximal inhibitory concentration: > 178000 nM
Compound 4: only a limit was reported (the forecaster's own chance of this, stated with the estimate: 85%); the middle value is on the limit's open side.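

In this assay compound 4 gives > 178000 nM, which is a limit of the assay. The steps to compound 4 from compound 1, compound 2 and compound 3 therefore cannot be read, as each has a limit at both ends. The compounds shown leave open whether these four differ at all in this assay, and how far each lies past its limit.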